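Swapping the aryl group on the core of compound 3

The source may report more compounds than this note shows. Statements on the series, on what has been measured and on what is new or still open speak of the compounds shown alone.

Three compounds share a common core and were tested in a functional assay on HepG2 cells (Homo sapiens) for cytotoxicity, read by MTT assay, with a stated time of 72 h; on this read-out lower numbers stand for stronger inhibition and higher numbers for weaker inhibition. Compound 1 `Cc1cc(=O)n(-c2ccccc2C(F)(F)F)nc1C(=O)Nc1ccc(Oc2ncnc3ccsc23)cc1` gives 9230 nM in this assay. Compound 2 `Cc1cc(=O)n(-c2ccc(F)cc2)nc1C(=O)Nc1ccc(Oc2ncnc3ccsc23)cc1` gives 2110 nM in this assay, and the change a 4.4-fold lower number from compound 1 to compound 2 (0.64 log units; beyond the scatter) is modest but real. Compound 3 `Cc1cc(=O)n(-c2ccccc2C(F)(F)F)nc1C(=O)Nc1ccc(Oc2ncnc3sccc23)cc1` reaches only the limit of this assay, and its value stands as > 40000 nM. Thus compound 3 sits at the weak end of the numbers seen so far, and the step of an at least 4.3-fold higher number from compound 1 to compound 3 (0.63 log units; beyond the scatter) is known only as a bound, as noted in the limit of > 40000 nM in this assay, at which 1 of the 3 values shown sits.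

Compound 4 `Cc1cc(=O)n(-c2ccc(F)c(F)c2)nc1C(=O)Nc1ccc(Oc2ncnc3sccc23)cc1` differs from compound 3 in one place: 3,4-difluorophenyl in place of 2-(trifluoromethyl)phenyl on an aromatic nitrogen. Among the measured compounds shown here, the only measured step that bears on this kind of change is the one in which the same aryl group on the aromatic nitrogen was replaced, namely a 4.4-fold lower number from compound 1 to compound 2 (0.64 log units; beyond the scatter). By analogy, a modest lowering of the number in this assay is expected from compound 3 to compound 4, though compound 3 is known only as a limit, so the size remains uncertain. The step is therefore expected to be an at least 2.6-fold lower number from compound 3 to compound 4 (0.42 log units; beyond the scatter). Compound 4 is estimated to give 15000 nM in this assay, within a range from 5000 nM to 60000 nM.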

Compound 4, half-maximal inhibitory concentration: 16800 nM
Compound 4: the middle estimate sits 1.1-fold (0.05 log units) below what was measured, and the stated range covers the measured number.
By their numbers in this assay, from the lowest: compound 2; then compounds 1 and 4 (each within the scatter of the next). At a limit, above all of these: compound 3.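

Changing the aryl group on the aromatic nitrogen gives an at least 2.3-fold lower number from compound 3 to compound 4 (0.37 log units; beyond the scatter), which shows that this position also responds when the oxygen carries the other group, not only on the background first seen. The direction matches a 4.4-fold lower number from compound 1 to compound 2 (0.64 log units; beyond the scatter), with 2-(trifluoromethyl)phenyl leaving in both steps, although the entering groups differ: 4-fluorophenyl in one and 3,4-difluorophenyl in the other. Compound 3 gives > 40000 nM, which is a limit of the assay, and the size of this step therefore stays a bound: the limit of > 40000 nM in this assay, at which 1 of the 4 values shown sits.

The compounds shown leave open whether 4-fluorophenyl would bring the same lowering on the background of compound 3, and how 3,4-difluorophenyl would read on the background of compound 1. They also leave open how an unsubstituted phenyl, a methoxyphenyl, or an aryl ring bearing an amine or a carboxylic acid would read at this position in this assay.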